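The compounds below may be only part of what the source reports. "The series", "measured", "known", "first", "only" and "open" are said of these compounds alone.

Measured so far in a functional assay on A549 cells (Homo sapiens) for antiproliferative activity, read by MTT assay, with a stated time of 48 h; a higher number here means a weaker inhibitor, a lower number a stronger inhibitor:
- compound 1 `CC(C)=CCC[C@]1(C)/C=C/[C@@H](OC(=O)C=C(C)C)[C@](C)(O)/C=C/C(=O)/C(C(=O)O)=C\C1`: > 10000 nM, a limit of the assay
- compound 2 `CC[Si](CC)(CC)C/C1=C/C[C@](C)(CCC=C(C)C)/C=C/[C@@H](OC(=O)C=C(C)C)[C@](C)(O)/C=C/C1=O`: 3100 nM

Among the compounds with values here, compound 2 holds the only actual number so far. Compound 3 `CC(C)=CCC[C@]1(C)/C=C/[C@@H](OC(=O)C=C(C)C)[C@](C)(O)/C=C/C(=O)/C(C[Si](C)(C)C(C)(C)C)=C\C1` has the same atoms as compound 2, joined differently: a group of 7 heavy atoms (6 carbon, 1 silicon; no ring) in place of a group of 7 heavy atoms (6 carbon, 1 silicon; no ring), on a saturated chain carbon bound to a double-bonded ring carbon, on a saturated chain carbon bound to a double-bonded ring carbon. Within the data shown here, the one measured step, an at least 3.2-fold lower number from compound 1 to compound 2 (0.50 log units; beyond the scatter), swapped a much more different group, so it bears only loosely on this change. No step beyond the scatter is therefore expected in this assay. The expected step is a 1.0-fold lower number from compound 2 to compound 3 (0.01 log units; within the scatter). Compound 3 is expected at 3000 nM, with an estimated range of 1200 nM to 8000 nM.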

Compound 3, half-maximal inhibitory concentration: 4200 nM
The estimate for compound 3 lay 1.4-fold (0.15 log units) below the measured number; low and high end bracket the measured number.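

In this assay, exchanging one silicon-bearing group for the other on this saturated chain carbon gives a 1.4-fold higher number from compound 2 to compound 3 (0.13 log units; within the scatter), so the two groups cannot be told apart here. Compound 3 also gives an at least 2.3-fold lower number from compound 1 to compound 3 (0.37 log units; beyond the scatter), so the lower number relative to compound 1 holds for both silicon-bearing groups. Compound 1 stands at a limit, not a number: the limit of > 10000 nM in this assay, at which 1 of the 3 values shown sits.

On these data alone, how a neopentyl group or an amine would read at this place remains open. Whether the silicon atom itself matters cannot be told from these compounds.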